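Solubility limits and the step to compound 4

A few compounds are considered here, and "the series" means these few. Any claim that something is new, unique, unknown or untested is made for them only; others in the source may bear on it.

Compound 1 `CNC(=O)c1cc(C(=O)NC2CC2)cn(Cc2ccc(F)cc2)c1=O` gives >= 162 ug/mL as a limit
Compound 2 `CNC(=O)c1cc(C(=O)NC2CC2)cn(Cc2cccc(F)c2)c1=O` gives >= 133 ug/mL as a limit
Compound 3 `CNC(=O)c1cc(C(=O)NC2CC2)cn(Cc2cccc3cn[nH]c23)c1=O` gives >= 181 ug/mL as a limit

All three entries in a physicochemical assay for solubility (a higher number here means a more soluble compound, a lower number a less soluble compound), are limits and none is a number. Compound 3 stands at >= 181 ug/mL as a limit, so it has no readable position against the two others.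

The change to compound 4 `CNC(=O)c1cc(C(=O)NC2CC2)cn(Cc2cccc3c2CCN3)c1=O` is 2,3-dihydro-1H-indol-4-yl in place of 1H-indazol-7-yl on a saturated chain carbon bound to an aromatic nitrogen and in words it puts 2,3-dihydro-1H-indol-4-yl in place of 1H-indazol-7-yl on a saturated chain carbon bound to an aromatic nitrogen.

For the measured compounds named here, three measured steps concern this same place. They are a step that the two limits leave unreadable from compound 1 to compound 3 and a step that the two limits leave unreadable from compound 2 to compound 3 and a step that the two limits leave unreadable from compound 1 to compound 2 and none of them gives a size to carry over. No step beyond the usual scatter is therefore expected in this assay and no direction is favoured. The estimate leans on compound 3 at >= 181 ug/mL as a limit and is loose for that reason. The estimated step is an at least 1.0-fold lower number from compound 3 to compound 4 (0.02 log units; that floor lies within the scatter) and it is expected to stay within the scatter. For compound 4 the expected value is 170 ug/mL with an estimated range of 75 ug/mL to 320 ug/mL and a limit in place of a number is the likelier report.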

Compound 4, solubility: >= 184 ug/mL
Compound 4: a limit, no number (the forecaster's own chance of this, stated with the estimate: 60%); at least 1.0-fold (0.03 log units) between middle value and limit.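

In this assay, compound 4 gives >= 184 ug/mL, a limit and not a number. For the compounds shown here, no step to compound 4 from compound 1, compound 2 or compound 3 can be read, as all four entries are limits. The compounds shown leave open how the groups on the saturated chain carbon bound to an aromatic nitrogen rank in solubility.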